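Swapping an aryl group for a hydroxyethyl chain

The source may hold more compounds than are shown below. What is called first, only, known or untested is meant among the compounds shown, and "the series" means these compounds.

Among the compounds with values here, compound 2 `COc1nc2ccc(Br)cc2cc1C(c1ccccc1)n1cc(-c2ccc(OC(F)(F)F)cc2)nn1` is one of two compounds measured in an ADME assay on HEK293 cells (Homo sapiens) for cytotoxicity, read by sulforhodamine B assay, with a stated time of 48 h, tested at 10 uM (a lower number here means less inhibition, a higher number more inhibition at the concentration tested (going by the name of the read-out)), where compound 2 gives 5.8%. Compound 1 `CCCCc1cn(C(c2ccccc2)c2cc3cc(Br)ccc3nc2OC)nn1` gives -3.47%, and the two values lie within the scatter of each other. Within the data shown here, the only comparable step, a number 9.3 percentage points higher from compound 1 to compound 2 (within the scatter), stayed within the scatter. Compound 3 `COc1nc2ccc(Br)cc2cc1C(c1ccccc1)n1cc(CCO)nn1` differs from compound 2 by 2-hydroxyethyl in place of 4-(trifluoromethoxy)phenyl on an aromatic carbon. Since both measured compounds show little inhibition, compound 3 is expected to give a step of a number 3.8 percentage points lower from compound 2 to compound 3 (within the scatter), none beyond the scatter. Compound 3 is therefore estimated at 2%, within a range of -12% to 16%.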

Compound 3, a percentage reported as inhibition, at one concentration (the size of the read-out at that concentration, not a potency): 4.54%
Compound 3: middle estimate off by 2.5 percentage points, on the low side; the measured number falls inside the stated range.
By their numbers in this assay, from the lowest: compounds 1, 3 and 2 (each within the scatter of the next).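

In this assay the step to 2-hydroxyethyl in place of 4-(trifluoromethoxy)phenyl is a number 1.3 percentage points lower from compound 2 to compound 3 (within the scatter), so this aromatic carbon has now carried both a ring and a short chain with a hydrogen-bond donor, without a change beyond the scatter. Hydroxy in place of ethyl on a saturated chain carbon gives a number 8 percentage points higher from compound 1 to compound 3 (within the scatter), which again is no readable change. No supporting evidence bears on these results.

Going by these compounds, whether an amine or a carboxylic acid on this carbon would move the number beyond the scatter stays open. So does the behaviour of these compounds at other concentrations.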